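Swapping the para substituent on the anilide ring

The source may hold more compounds than are shown below. What is called first, only, known or untested is meant among the compounds shown, and "the series" means these compounds.

Measured compounds:
- Compound 1, `C=C(Br)C(=O)Nc1cccc(/C=C/C(=O)Nc2ccc(F)c(F)c2)c1`: 1900 nM
- Compound 2, `C=C(Br)C(=O)Nc1cccc(/C=C/C(=O)Nc2ccc(C)cc2)c1`: 1500 nM

Both compounds were tested in a functional assay on HeLa cells (Homo sapiens) for inhibition, read by MTT assay, with a stated time of 72 h; on this read-out lower numbers stand for stronger inhibition and higher numbers for weaker inhibition. Within the data shown here, compound 2 gives 1500 nM, the lowest of the two numbers, but its only neighbour, compound 1, sits a 1.3-fold lower number from compound 1 to compound 2 (0.10 log units; within the scatter), so the two cannot be told apart on these numbers. Compound 3, `C=C(Br)C(=O)Nc1cccc(/C=C/C(=O)Nc2ccc(OC(F)(F)F)cc2)c1`, has not been measured yet. It keeps the shared core of compound 2 and differs only at the anilide ring: trifluoromethoxy in place of methyl on an aromatic carbon.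

Among the measured compounds shown here, the one step already measured, a 1.3-fold lower number from compound 1 to compound 2 (0.10 log units; within the scatter), also changed the substituent on this same aromatic ring, and it moved the number hardly at all. On that basis the step to compound 3 is expected to stay small, with no clear direction beyond the scatter, as no change at the digits printed from compound 2 to compound 3 (within the scatter). Compound 3 is therefore estimated at 1500 nM, with a plausible range from 600 nM to 4000 nM.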

Compound 3, half-maximal inhibitory concentration: 29000 nM
Beside the measured number, compound 3's estimate is 19-fold (1.29 log units) below it; measured number above the stated range.
By their numbers in this assay, from the lowest: compounds 2 and 1 (each within the scatter of the next); then compound 3.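

In this assay, the position on the aromatic ring para to a large group proves sensitive to what sits there: trifluoromethoxy in place of methyl gives a 19-fold higher number from compound 2 to compound 3 (1.29 log units; beyond the scatter). The earlier change on this ring, a 1.3-fold lower number from compound 1 to compound 2 (0.10 log units; within the scatter), gave no hint of this, so the ring accepts some changes with no readable effect on the number, while this single replacement weakens inhibition sharply. The swap replaces one carbon with a group of five heavy atoms, among them an oxygen that counts as a hydrogen-bond acceptor and three fluorines, but nothing available here explains the weaker inhibition.

One replacement cannot show which part of the trifluoromethoxy group matters, so the oxygen and the fluorines remain unseparated; a methoxy group or a trifluoromethyl group at the same position would begin to pull them apart. As far as these compounds go, how the number responds to quite different groups there, such as an amine, a carboxylic acid or a longer alkyl chain, also remains open.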